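A few compounds are considered here, and "the series" means these few. Any claim that something is new, unique, unknown or untested is made for them only; others in the source may bear on it.

Measured in an assay on microsomes from brain (strain Sprague-Dawley) for inhibition of Fatty-acid amide hydrolase 1 (Rattus norvegicus), read by fluorescence and HPLC, with stated times of 10 min and 60 min; a lower number here means a stronger inhibitor, a higher number a weaker inhibitor:
compound 1, `O=C(NCCCCCCn1ccc2ccccc21)Oc1cccnc1`: 5.2 nM
compound 2, `O=C(NCCCCCn1ccc2ccccc21)Oc1ccccc1`: 94 nM
compound 3, `O=C(NCCCCCCn1ccc2ccccc21)Oc1ccccc1`: 250 nM

Compound 4, `O=C(NCCCCCn1ccc2ccccc21)Oc1cccnc1`, is not yet measured in this assay. It differs from compound 2 by pyridin-3-yl in place of phenyl on an oxygen next to a carbonyl group. The same change has been made once before in the set: compound 1 differs from compound 3 by pyridin-3-yl in place of phenyl on an oxygen next to a carbonyl group, and in this assay that gave a 48-fold lower number from compound 3 to compound 1 (1.68 log units; beyond the scatter). The two places are described in the same words, so the change is the same one. Within the data shown here, compound 2 and compound 3 have different cores; the difference between the two cores is not broken down here, and the values show only that compound 2 gives the lower number of the two.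

Among the measured compounds shown here, for compound 4 the step is expected to be of similar size, a 38-fold lower number from compound 2 to compound 4 (1.58 log units; beyond the scatter), because the one earlier example of this change gave a 48-fold lower number from compound 3 to compound 1 (1.68 log units; beyond the scatter). With a single precedent the expectation is held loosely. Compound 4 is estimated at 2.5 nM in this assay, within 0.6 nM to 12 nM.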

Compound 4, half-maximal inhibitory concentration: 3.6 nM
The estimate for compound 4 lay 1.4-fold (0.16 log units) below the measured number, and the stated range covers the measured number.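

In this assay, pyridin-3-yl in place of phenyl on an oxygen next to a carbonyl group again gives a large step, a 26-fold lower number from compound 2 to compound 4 (1.42 log units; beyond the scatter), so the change has now carried from one core to a second. The two steps cannot be told apart in size: the same change on two cores in this assay, a 48-fold lower number (1.68 log units; beyond the scatter) from compound 3 to compound 1 and a 26-fold lower number (1.42 log units; beyond the scatter) from compound 2 to compound 4, 1.8-fold (0.27 log units) apart, within the scatter of two such steps. Among these compounds, this rests on only two cores and shows neither why the step arises nor whether it would hold on a core further removed from these two.

The compounds shown leave open how pyridin-2-yl or pyridin-4-yl would read in the same place. They also leave open whether a shorter or longer chain would keep a step of this size.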